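From compound 2 to compound 3 in growth inhibition

The source may report more compounds than this note shows. Statements on the series, on what has been measured and on what is new or still open speak of the compounds shown alone.

Measured in a functional assay on A549 cells (Homo sapiens) for inhibition; a lower number here means a stronger inhibitor of growth, a higher number a weaker inhibitor of growth
compound 1 `C/C=C/C=C/C(=O)C[C@H](CCO)OC` gives 50000 nM
compound 2 `C/C=C/C=C/C(=O)CC(CCO)OCC[C@H](O)CC(=O)CC/C=C/C` gives 28000 nM

Compound 2 stands within the usual scatter of compound 1, so these two numbers set no order between them. Compound 3 `C/C=C/C=C/C(=O)CC(CCO)OCC[C@H](O)CC(=O)/C=C/C=C/C` has not yet been measured. It differs from compound 2 in one place, where penta-1,3-dien-1-yl takes the place of pent-3-en-1-yl on a carbonyl carbon (penta-1,3-dien-1-yl in place of pent-3-en-1-yl on a carbonyl carbon). Among the compounds with values here, no measured step shows what this change does, and the only anchor is the value of compound 2 (28000 nM). A small move toward stronger growth inhibition is therefore expected, probably not beyond the scatter. The estimated change is a 1.8-fold lower number from compound 2 to compound 3 (0.24 log units; within the scatter) in this direction. In this assay compound 3 is expected at 16000 nM (estimated range 4000 nM to 50000 nM).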

Compound 3, concentration for 50% growth inhibition: 29000 nM
Estimate against measurement, compound 3: 1.8-fold (0.26 log units) below; low and high end bracket the measured number.
By their numbers in this assay, from the lowest: compounds 2, 3 and 1 (each within the scatter of the next).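

In this assay, within the data shown here, penta-1,3-dien-1-yl in place of pent-3-en-1-yl on a carbonyl carbon gives a 1.0-fold higher number from compound 2 to compound 3 (0.02 log units; within the scatter), the first step that can be read at this place. The group leaving has one double bond and the group entering has two, yet this difference in the five-carbon group sets no order between the two compounds in growth inhibition. Nothing available here offers an explanation for this result.

Going by these compounds, whether an amine, a carboxylic acid or a longer chain on this carbonyl carbon would give a number beyond the scatter of compound 2 stays open. With only this one step at the position, the compounds shown do not tell whether growth inhibition responds to any change made there.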